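Cyclopropyl on the Amide Nitrogen of Compound 3

The source may hold more compounds than are shown below. What is called first, only, known or untested is meant among the compounds shown, and "the series" means these compounds.

Compound 3 `CCCNC(=O)/C=C1\CCc2ccc(F)cc21` stands highest of the three measured compounds in a functional assay on the whole organism with Mus musculus as the target, at a dose of 100 mg/kg by the intraperitoneal route (a higher number here means more inhibition at the dose given (going by the name of the read-out), a lower number less inhibition), where compound 3 gives 100%. Compound 1 `O=C(/C=C1\CCc2ccc(F)cc21)NCC1CC1` gives 50% in this assay, and compound 2 `O=C(/C=C1\CCc2ccc(Cl)cc21)NC1CC1` gives 50%. Going by the values given here, the one measured step between compounds that differ in a single place, a number 50 percentage points higher from compound 1 to compound 3 (beyond the scatter), shows the propyl amide well ahead of the compound that carries the cyclopropyl on a saturated chain carbon bound to the amide-type nitrogen. Compound 4 `O=C(/C=C1\CCc2ccc(F)cc21)NC1CC1` differs from compound 3 by cyclopropyl in place of propyl on an amide-type nitrogen. Among the compounds with values here, no measured step covers this exact change. The step from compound 1 to compound 3 bears on it, since it also exchanges a propyl group against a cyclopropyl-containing group on the amide side, and there the cyclopropyl-containing compound gave the lower number by a large margin. Compound 2 also carries a cyclopropyl on the amide-type nitrogen and shows 50%, although compound 2 differs from compound 4 elsewhere as well. On these grounds a downward step is expected, a number 45 percentage points lower from compound 3 to compound 4 (beyond the scatter), beyond the scatter. Compound 4 is therefore estimated at 55%, with a range from 25% to 90%.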

Compound 4, a percentage reported as inhibition, in the whole organism at one dose (the size of the read-out at that dose, not a potency): 100%
Beside the measured number, compound 4's estimate is 45 percentage points below it; measured number above the stated range.
By their numbers in this assay, from the lowest: compounds 1 and 2 (each within the scatter of the next); then compounds 3 and 4 (each within the scatter of the next).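

On the amide-type nitrogen, cyclopropyl and propyl cannot be told apart in this assay, with no change at the digits printed from compound 3 to compound 4 (within the scatter), so a cyclopropyl ring on this nitrogen does not in itself go with a lower number. Where the ring stands on the amide side does make a difference here, since cyclopropyl in place of cyclopropylmethyl gives a number 50 percentage points higher from compound 1 to compound 4 (beyond the scatter), which ties the low number of compound 1 to the cyclopropylmethyl group and not to cyclopropyl as such. Going by these compounds alone, the result also gives the first measured step at the aromatic carbon, where fluoro in place of chloro gives a number 50 percentage points higher from compound 2 to compound 4 (beyond the scatter), so with cyclopropyl on the nitrogen in both compounds, the low number of compound 2 goes with the chloro group.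

As far as these compounds go, because the read-out is taken at a single dose and is not a potency, it remains open whether compound 3 and compound 4 would still match at lower doses. Also open, from the compounds shown here alone, is how a longer chain such as butyl on the amide-type nitrogen, or bromo or methoxy on the aromatic carbon, would compare. No evidence at hand speaks to why these steps take the sizes they do.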